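A few compounds are considered here, and "the series" means these few. Any claim that something is new, unique, unknown or untested is made for them only; others in the source may bear on it.

Measured so far in an ADME assay on HepG2 cells (Homo sapiens) for cytotoxicity, read by MTT assay, with a stated time of 48 h; on this read-out higher numbers stand for weaker inhibition and lower numbers for stronger inhibition:
- compound 1, `C/C(=N/c1ccnc2cc(Cl)ccc12)NCCCCN1CCCCC1`, gives 9.81 ug/mL
- compound 2, `C/C(=N/c1ccnc2cc(Cl)ccc12)NC1CCN(C)CC1`, gives > 30.3 ug/mL
- compound 3, `CN(C)CCC/N=C(\c1ccccc1)N(CCCN(C)C)c1ccnc2cc(Cl)ccc12`, gives 5.77 ug/mL

Compound 2 returned only a limit of this assay, not a number, which is the meaning of the limit of > 30.3 ug/mL in this assay, at which 1 of the 3 values shown sits, here. Among the two compounds that gave numbers, compound 1 and compound 3 sit apart by a gap that is within the usual scatter of this kind of measurement, so nothing about order between them can be read from these two values. Compound 1 therefore stands simply as one of two similar numbers, with compound 2 off at the limit.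

Compound 4, `C/C(=N/c1ccnc2cc(Cl)ccc12)NCCCN1CCCCC1`, is the next compound to be measured. It differs from compound 1 in one place: piperidin-1-yl in place of (piperidin-1-yl)methyl on a saturated chain carbon, three bonds along the chain from an amine nitrogen. The shared core and the amine-bearing chain end are kept; only the chain between them is one carbon shorter.

For the measured compounds named here, no measured step between two compounds of this set is available to guide the expectation, so the shortening of the chain is expected to move the number little, if at all beyond the scatter. The step from compound 1 to compound 4 is expected to be a 1.1-fold higher number from compound 1 to compound 4 (0.03 log units; within the scatter). Compound 4 is thus estimated at 10.5 ug/mL, within a range from 4.5 ug/mL to 25 ug/mL.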

Compound 4, half-maximal inhibitory concentration: 23.3 ug/mL
The estimate for compound 4 lay 2.2-fold (0.35 log units) below the measured number; the measured number falls inside the stated range.
By their numbers in this assay, from the lowest: compounds 3 and 1 (each within the scatter of the next); then compound 4. At a limit, above all of these: compound 2.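

Swapping (piperidin-1-yl)methyl for piperidin-1-yl on a saturated chain carbon, three bonds along the chain from an amine nitrogen, gives in this assay a 2.4-fold higher number from compound 1 to compound 4 (0.38 log units; beyond the scatter). For the compounds shown here, this is the first step in the set between two compounds that differ in one place, and it shows that the length of this chain is not neutral: with the shared core and the piperidine end kept, the shorter chain goes with weaker inhibition of the cells, by a modest but real margin. Going by these compounds alone, nothing measured so far accounts for why this shortening moves the number.

On these data alone, a single step gives two chain lengths and so no trend, and it remains open whether a longer chain would continue this direction, level off or reverse it. As far as these compounds go, it is also open whether the same dependence on chain length would hold with a different amine at the chain end, such as a diethylamino group in place of the piperidine.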